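Thiazolidinone and oxazolidinone carboxamides on HOS-TE85 cells

The source may report more compounds than this note shows. Statements on the series, on what has been measured and on what is new or still open speak of the compounds shown alone.

Measured so far:
- compound 1 `COc1ccccc1N1C(=O)CSC1C(=O)NCCCCc1ccccc1`, in a functional assay on HOS-TE85 cells (Homo sapiens) for inhibition, read by CCK-8 assay, with a stated time of 72 h, tested at 1 uM (on this read-out lower numbers stand for less inhibition and higher numbers for more inhibition at the one concentration tested (going by the name of the read-out)), compound 1 gives 0%
- compound 2 `Cc1cccc(N2C(=O)CSC2c2cccc(C(=O)NCCCCc3ccccc3)c2)c1`, in this assay compound 2 gives 96%
- compound 3 `O=C(NCCCCc1ccccc1)c1cccc(C2OCC(=O)N2c2cccc(F)c2)c1`, in this assay compound 3 gives 87%

Compound 2 gives the highest of the three numbers. The nearest number is that of compound 3, which lies within the scatter of repeated measurement, so the two cannot be told apart on this read-out. Compound 1 is far lower, beyond the scatter; it lacks the benzamide spacer and carries a 2-methoxyphenyl on the ring nitrogen, so several things differ at once and no single cause can be read from its value.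

Compound 4 `O=C(NCCCCc1ccccc1)c1cccc(C2SCC(=O)N2c2ccccc2F)c1` has not yet been measured in this assay. Against compound 2 the change is 2-fluorophenyl in place of 3-methylphenyl on an amide-type nitrogen in a ring. The new group sits on an amide-type nitrogen in a ring of a five-membered non-aromatic ring with 1 nitrogen and 1 sulfur. Going by the values given here, no pair of measured compounds differs in this one place alone, so the step has no direct precedent. Compound 3 shows that a fluorophenyl on the ring nitrogen is compatible with a high number, though on a ring with oxygen in place of sulfur.

For compound 4 a step from compound 2 of a number 18 percentage points lower from compound 2 to compound 4 (beyond the scatter) is expected in this assay, a small loss or none beyond the scatter. Compound 4 is estimated at 78%, with a range from 40% to 96%.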

Compound 4, a percentage reported as inhibition, at one concentration (the size of the read-out at that concentration, not a potency): 95%
Beside the measured number, compound 4's estimate is 17 percentage points below it; the range from low to high includes it.
By their numbers in this assay, from the lowest: compound 1; then compounds 3, 4 and 2 (each within the scatter of the next).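

In this assay, 2-fluorophenyl in place of 3-methylphenyl on the amide-type nitrogen in a ring gives a number 1 percentage points lower from compound 2 to compound 4 (within the scatter), so the two groups cannot be told apart at this position on this read-out. Going by these compounds alone, this is the first direct step at this position, and it shows that the position does not depend on the methyl group to keep a high number. Within the data shown here, compound 4 gives 95%, which also shows that a fluorophenyl on the ring nitrogen can give a high number when the ring holds sulfur, a case the earlier compounds did not cover. No measurement bearing on the reason for this result is at hand.

Going by these compounds, each number comes from a single concentration and is not a potency, so it remains open whether compound 2 and compound 4 would separate at lower concentrations. Also open, on these data alone, is whether a group of a different kind on this phenyl ring, such as a carboxylic acid or a dimethylamino group, would keep the number high, and the very low number of compound 1 still cannot be traced to any one of its differences.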